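Trimethoxyphenyl pyrazole chalcones: removing one methoxy

The source may hold more compounds than are shown below. What is called first, only, known or untested is meant among the compounds shown, and "the series" means these compounds.

Measured compounds:
compound 1 `COc1cc(-c2cc(/C=C/C(=O)c3ccc(N)cc3)[nH]n2)cc(OC)c1OC` 8510 nM
compound 2 `COc1cc(-c2cc(/C=C/C(=O)c3ccc(Cl)c(Cl)c3)[nH]n2)cc(OC)c1OC` 40600 nM
compound 3 `COc1ccc(C(=O)/C=C/c2cc(-c3cc(OC)c(OC)c(OC)c3)n[nH]2)cc1OC` 5560 nM

In a functional assay on MOLT-4 cells (Homo sapiens) for inhibition, read by sulforhodamine B assay, with a stated time of 48 h (on this read-out higher numbers stand for weaker inhibition of growth and lower numbers for stronger inhibition of growth), compound 3 gives the lowest of the three numbers. Compound 1 sits nearest, a gap within the scatter, so no order between compound 3 and compound 1 can be claimed; compound 2 sits furthest, as a 7.3-fold lower number from compound 2 to compound 3 (0.86 log units; beyond the scatter) shows, a gap beyond the scatter.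

Compound 4 `COc1ccc(C(=O)/C=C/c2cc(-c3cc(OC)c(OC)c(OC)c3)n[nH]2)cc1` differs from compound 3 by hydrogen in place of methoxy on an aromatic carbon. The change sits on the aryl attached to the carbonyl carbon, on an aromatic carbon of a six-membered aromatic ring of carbon only, ortho to a methoxy group and meta to a large group.

For the measured compounds named here, none of the measured steps removes a single methoxy from this ring; each swaps the whole aryl on the carbonyl carbon. The nearest precedents are a 1.5-fold lower number from compound 1 to compound 3 (0.18 log units; within the scatter), which is within the scatter, and a 7.3-fold lower number from compound 2 to compound 3 (0.86 log units; beyond the scatter), which is beyond it. Loss of one methoxy is a smaller change than either swap, so in this assay a step of at most modest size is expected, with a slightly higher number more likely than a lower one.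

For compound 4 the expected value in this assay is 7500 nM, range 2500 nM to 22000 nM. The step from compound 3 this implies is estimated as a 1.3-fold higher number from compound 3 to compound 4 (0.13 log units; within the scatter).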

Compound 4, concentration for total growth inhibition: 6820 nM
Compound 4: the middle estimate sits 1.1-fold (0.04 log units) above what was measured; measured number inside the range.
By their numbers in this assay, from the lowest: compounds 3, 4 and 1 (each within the scatter of the next); then compound 2.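

For the compounds shown here, removing one methoxy, which turns 3,4-dimethoxyphenyl into 4-methoxyphenyl, is the first single-group change at this aromatic carbon in this assay, and the step stays within the scatter (a 1.2-fold higher number from compound 3 to compound 4 (0.09 log units; within the scatter)). Going by these compounds alone, this methoxy is therefore not needed to hold the read-out at the level of compound 3, whereas the earlier steps swapped the whole aryl on the carbonyl carbon and could not separate the contribution of this one group. The 4-methoxyphenyl of compound 4 also cannot be told apart from the 4-aminophenyl of compound 1 (a 1.2-fold lower number from compound 1 to compound 4 (0.10 log units; within the scatter)), while the gap to the 3,4-dichlorophenyl of compound 2 stays beyond the scatter (a 6.0-fold lower number from compound 2 to compound 4 (0.77 log units; beyond the scatter)), so compound 2 alone stands apart among the four.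

No supporting data bear on why this methoxy can go without a readable change. Still open, as far as these compounds go, is whether the remaining methoxy is equally dispensable, as in an unsubstituted phenyl, and how a hydroxy group, an ethoxy group or a carboxylic acid would read at the aromatic carbon vacated in compound 4.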